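The compounds below may be only part of what the source reports. "The series", "measured", "known", "first", "only" and "open" are said of these compounds alone.

In a functional assay on the whole organism with Mus musculus as the target (on this read-out lower numbers stand for smaller maximal responses and higher numbers for larger maximal responses), two compounds have been measured so far:

compound 1, `NC(=O)Cn1c(=O)n(C2OC(CO)[C@@H](O)[C@H]2O)c2nc(N)nc(O)c21` — 72%
compound 2, `C=CCn1c(=O)n(C2C[C@H](O)C(CO)O2)c2nc(N)nc(O)c21` — 131%

For the measured compounds named here, compound 1 stands at the lower of the two numbers; compound 2, which carries a different group on the ring nitrogen and a different sugar, reaches a response that lies well beyond the usual scatter above it, but these two differ in more than one place and no single step joins them.

The account now turns to compound 3, `Cn1c(=O)n(C2OC(CO)[C@@H](O)[C@H]2O)c2nc(N)nc(O)c21`, which has not yet been measured in this assay. It differs from compound 1 in one place: hydrogen in place of carbamoyl on a saturated chain carbon bound to an aromatic nitrogen. Going by the values given here, since no measured pair shows this change, the step can only be expected, not read off. A modest rise from compound 1 is expected, a number 18 percentage points higher from compound 1 to compound 3 (beyond the scatter), though a result within the scatter would not be surprising. The estimate for compound 3 is therefore 90%, within a range from 55% to 130%.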

Compound 3, largest response reached (reported as maximal response), in percent of the reference or control that the assay uses: 100%
Compound 3: the middle estimate sits 10 percentage points below what was measured, within the range that was stated.
By their numbers in this assay, from the lowest: compound 1; then compound 3; then compound 2.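

In this assay, for the compounds shown here, the change from carbamoylmethyl to methyl gives a number 28 percentage points higher from compound 1 to compound 3 (beyond the scatter) as the first step that can be read at a single place. It shows that the number responds to this group alone, which the earlier pair could not show, since those compounds also differ in the sugar. On a saturated chain carbon bound to an aromatic nitrogen, then, the carbamoyl is not needed for a response, and its loss goes with a larger one, while nothing at hand gives a reason for this shift.

The compounds shown leave open whether a carboxylic acid or an amine in place of the carbamoyl would give a similar number. They also leave open whether this step would hold on the sugar of compound 2.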